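The source may report more compounds than this note shows. Statements on the series, on what has been measured and on what is new or still open speak of the compounds shown alone.

Compound 1 `COc1ccc(C2=NN(C3=NC(=O)/C(=C4\C(=O)Nc5ccccc54)S3)C(c3ccc(OC)cc3)C2)cc1`: 89200 nM in a functional assay on cells (Cancer cell lines, Homo sapiens) for cytotoxicity, read by sulforhodamine B assay, with a stated time of 48 h; on this read-out lower numbers stand for stronger inhibition of growth and higher numbers for weaker inhibition of growth
Compound 2 `COc1ccc(C2=NN(C3=NC(=O)/C(=C4\C(=O)Nc5ccc(Cl)cc54)S3)C(c3ccc(OC)cc3)C2)cc1`: 420 nM in this assay
Compound 3 `COc1ccc(C2=NN(C3=NC(=O)/C(=C4\C(=O)Nc5ccccc54)S3)C(c3ccc(Cl)cc3)C2)cc1`: 100000 nM in this assay

Among these three, compound 3 gives the highest number in this assay. Its number and that of compound 1 lie within the scatter of each other, so the two cannot be told apart, while compound 2 sits far lower, with a 210-fold lower number from compound 1 to compound 2 (2.33 log units; beyond the scatter).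

Compound 4 `COc1ccc(C2=NN(C3=NC(=O)/C(=C4\C(=O)Nc5ccc(Cl)cc54)S3)C(c3ccc(Cl)cc3)C2)cc1` has not yet been measured. It differs from compound 3 in one place: chloro in place of hydrogen on an aromatic carbon, on an aromatic carbon of a six-membered aromatic ring of carbon only, part of a fused system of two rings, meta to a fused ring and para to a fused ring. This is the very change already seen once in this series. The step of a 1.1-fold higher number from compound 1 to compound 3 (0.05 log units; within the scatter) concerns a different position and says nothing about it. The step of a 210-fold lower number from compound 1 to compound 2 (2.33 log units; beyond the scatter) is the only one that bears on it, and it was large. A drop of comparable size is therefore expected, that is a 200-fold lower number from compound 3 to compound 4 (2.30 log units; beyond the scatter), because a 210-fold lower number from compound 1 to compound 2 (2.33 log units; beyond the scatter) came from the same replacement at the same place.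

Compound 4 is thus estimated at 500 nM in this assay, with a range from 100 nM to 3000 nM.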

Compound 4, concentration for total growth inhibition: 430 nM
Compound 4: the middle estimate sits 1.2-fold (0.07 log units) above what was measured, within the range that was stated.
By their numbers in this assay, from the lowest: compounds 2 and 4 (each within the scatter of the next); then compounds 1 and 3 (each within the scatter of the next).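

In this assay, chloro in place of hydrogen on this carbon of the fused system of two rings again brings a large drop when the core carries chloro instead of methoxy elsewhere, with a 230-fold lower number from compound 3 to compound 4 (2.37 log units; beyond the scatter). The earlier compounds showed this drop on one core only, whereas it now appears on two cores at nearly the same size: the same change on two cores in this assay, a 210-fold lower number (2.33 log units; beyond the scatter) from compound 1 to compound 2 and a 230-fold lower number (2.37 log units; beyond the scatter) from compound 3 to compound 4, 1.1-fold (0.04 log units) apart, within the scatter of two such steps The second replacement, chloro in place of methoxy on an aromatic carbon, had been seen only without the chloro on the fused system, and it now gives a 1.0-fold higher number from compound 2 to compound 4 (0.01 log units; within the scatter), so neither core shows a readable difference from it: the same change on two cores in this assay, a 1.1-fold higher number (0.05 log units; within the scatter) from compound 1 to compound 3 and a 1.0-fold higher number (0.01 log units; within the scatter) from compound 2 to compound 4, 1.1-fold (0.04 log units) apart, within the scatter of two such steps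

The compounds shown carry only hydrogen or chloro at this position on the fused system, so it stays open whether a bromo group, a methyl group or an amine there would bring a drop of similar size. They also carry only methoxy or chloro at the other replaced carbon, leaving open whether a carboxylic acid or a longer chain there would make as little difference.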